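The source may hold more compounds than are shown below. What is called first, only, known or untested is meant among the compounds shown, and "the series" means these compounds.

Three compounds share one core and differ only in the group carried on a nitrogen on an aromatic ring. Compound 1 `Cc1ccccc1Nc1nc(NC2CC2)ncc1Cl` carries cyclopropyl there. In a functional assay on Jurkat cells (Homo sapiens) for inhibition, read by CCK-8 assay, with a stated time of 48 h (a lower number here means a stronger inhibitor of growth, a higher number a weaker inhibitor of growth), compound 1 gives > 100000 nM, which is a limit of the assay rather than a number. Compound 2 `Cc1ccccc1Nc1nc(NC2CCCCC2)ncc1Cl` carries cyclohexyl. In this assay compound 2 gives > 100000 nM, again a limit. Compound 3 `Cc1ccccc1Nc1nc(NCc2ccccc2)ncc1Cl` carries benzyl. In this assay compound 3 gives > 100000 nM, also a limit. Because of the limit of > 100000 nM in this assay, at which 3 of the 3 values shown sit, none of the steps among them can be read: a step that the two limits leave unreadable from compound 1 to compound 2, a step that the two limits leave unreadable from compound 1 to compound 3 and a step that the two limits leave unreadable from compound 2 to compound 3 all stay unreadable. Compound 3 thus stands at the limit, with no number to set it apart from the other two.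

Compound 4 `Cc1ccccc1Nc1nc(NCc2ccncc2)ncc1Cl` is the untested compound. Its difference from compound 3 is pyridin-4-yl in place of phenyl on a saturated chain carbon bound to a nitrogen on an aromatic ring. Among the compounds with values here, no measured step touches a change of this kind; the three known steps are hidden by limits and give neither size nor direction. Compound 4 is therefore expected to sit at the limit as well. The expected step of a number no higher from compound 3 to compound 4 (the limit leaves the size open) is none beyond the scatter. Compound 4 is estimated at 100000 nM in this assay, within a range from 30000 nM to 300000 nM.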

Compound 4, concentration for 50% growth inhibition: > 100000 nM
Compound 4: no number, only a limit; the forecaster's own chance of this, stated with the estimate: 80%; the middle value lies on the limit itself.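

None of the steps from compound 1, compound 2 or compound 3 to compound 4 can be read, because each of these compounds gives a limit rather than a number: the limit of > 100000 nM in this assay, at which 4 of the 4 values shown sit.

The compounds shown leave open whether swapping among cyclopropyl, cyclohexyl, benzyl and (pyridin-4-yl)methyl on a nitrogen on an aromatic ring changes growth inhibition at all, and in which direction.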